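Removing One Chloro Group from an Aryloxy Propanediol

The source may hold more compounds than are shown below. What is called first, only, known or untested is meant among the compounds shown, and "the series" means these compounds.

Three aryl ethers have been measured in a physicochemical assay for lipophilicity, measured as octanol-water partition; a lower number here means a more polar compound, a higher number a more lipophilic compound. Compound 1 `Cc1ccccc1OCCCO` gives 2.34 in this assay. Compound 2 `Cc1cccc(Cl)c1OCCCO` gives 2.93, and compound 3 `OCC(O)COc1ccc(Cl)cc1Cl` gives 1.99, the lowest of the three numbers. The change from compound 2 to compound 1 is hydrogen in place of chloro on an aromatic carbon, and this assay moved a number 0.59 log units lower from compound 2 to compound 1 (beyond the scatter). How the core of compound 3 differs from that of compound 2 is not broken down here; their values simply show compound 3 standing lower than compound 2.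

Compound 4 `OCC(O)COc1ccccc1Cl` has not yet been measured in this assay. It differs from compound 3 by hydrogen in place of chloro on an aromatic carbon. Going by the values given here, this is the same kind of change as the one from compound 2 to compound 1, though its surroundings differ: in compound 1 the new hydrogen sits ortho to a group of 5 heavy atoms and meta to a methyl group, whereas in compound 4 it sits meta to a chloro group and para to a group of 6 heavy atoms.

Since the earlier step was a number 0.59 log units lower from compound 2 to compound 1 (beyond the scatter), a step of similar size is expected here, estimated at a number 0.59 log units lower from compound 3 to compound 4 (beyond the scatter). Compound 4 is therefore expected to give about 1.4 in this assay, most likely between 1.1 and 1.7.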

Compound 4, partition coefficient: 1.29
The estimate for compound 4 lay 0.11 log units above the measured number, and the stated range covers the measured number.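

In this assay, hydrogen in place of chloro on an aromatic carbon gave a number 0.70 log units lower from compound 3 to compound 4 (beyond the scatter), which runs the same way as a number 0.59 log units lower from compound 2 to compound 1 (beyond the scatter), so the change carried from the core of compound 2 to the core of compound 3 in direction, and both steps are modest. Going by these compounds alone, this rests on only two pairs, and the hydrogen enters different surroundings in them: in compound 4 it sits meta to a chloro group and para to a group of 6 heavy atoms, so the pairs show agreement between these two cores and no general rule for the series or for other positions on the ring. Nothing available here accounts for either step or for how the two compare in size.

The compounds shown leave open whether the same step would appear on a core whose side chain carries an amine or a carboxylic acid, or on one with a longer chain. They also leave open how fluoro or bromo would compare with chloro at the same place, and what would follow from replacing the remaining chloro group of compound 4 with hydrogen.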